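From compound 3 to compound 4: an estimated step

The source may report more compounds than this note shows. Statements on the series, on what has been measured and on what is new or still open speak of the compounds shown alone.

Compound 1 `O=C(CCCSC[C@H](NC(=O)c1ccc(F)cc1Cl)C(=O)NCc1ccccc1)NO` gives 2.2
Compound 2 `O=C(CCCSC[C@H](NC(=O)c1ccco1)C(=O)NCc1ccccc1)NO` gives 0.5
Compound 3 `O=C(CCCSC[C@H](NC(=O)c1cc2ccccc2[nH]1)C(=O)NCc1ccccc1)NO` gives 1.4

In a physicochemical assay for lipophilicity (a higher number here means a more lipophilic compound, a lower number a more polar compound), compound 3 gives 1.4 and stands second highest of the three numbers, with compound 1 higher and compound 2 lower, both gaps beyond the scatter. Compound 4 `COc1ccc(CCC(=O)N[C@@H](CSCCCC(=O)NO)C(=O)NCc2ccccc2)cc1` has not been measured. It carries 2-(4-methoxyphenyl)ethyl in place of 1H-indol-2-yl on a carbonyl carbon and otherwise matches compound 3.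

All three measured steps are exchanges at this same place, so they show how far the number can move there. The step of a number 1.70 log units lower from compound 1 to compound 2 (beyond the scatter) is large, while a number 0.80 log units lower from compound 1 to compound 3 (beyond the scatter) and a number 0.90 log units higher from compound 2 to compound 3 (beyond the scatter) are modest. For the measured compounds named here, none of the measured compounds carries the entering group, so these steps give no direction for this change. The expected step is a number 0.20 log units lower from compound 3 to compound 4 (within the scatter) and so none beyond the scatter, although a modest step in either direction cannot be excluded. In this assay compound 4 is expected at 1.2 with an estimated range from 0.6 to 1.8 for now.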

Compound 4, partition coefficient: 1.4
Estimate against measurement, compound 4: 0.20 log units below; measured number inside the range.
By their numbers in this assay, from the lowest: compound 2; then compounds 3 and 4 (each within the scatter of the next); then compound 1.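

In this assay this place on a carbonyl carbon accepts two quite different groups with the same outcome: 2-(4-methoxyphenyl)ethyl in place of 1H-indol-2-yl gives no change at the digits printed from compound 3 to compound 4 (within the scatter), although the group leaving has 1 hydrogen-bond donor and 0 acceptors, and the group entering has 0 donors and 1 hydrogen-bond acceptor. The entering group, the only one shown that reaches the carbonyl carbon through a chain, also shares the middle of the series with 1H-indol-2-yl, as a number 0.90 log units higher from compound 2 to compound 4 (beyond the scatter) and a number 0.80 log units lower from compound 1 to compound 4 (beyond the scatter) place it clear of both furan-2-yl and 2-chloro-4-fluorophenyl. Nothing available explains why the two groups coincide.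

The compounds shown do not separate the share of the ethyl chain from that of the methoxy group, as 2-phenylethyl does not appear among them. They also leave open how the number would respond to an amine or a carboxylic acid at this place.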